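The compounds below may be only part of what the source reports. "The series", "measured", "known", "first", "only" and "open" are said of these compounds alone.

In a functional assay on A549 cells (Homo sapiens) for antiproliferative activity, read by MTT assay, with a stated time of 72 h (on this read-out lower numbers stand for stronger inhibition and higher numbers for weaker inhibition), compound 1 `COc1cc2ncnc(Nc3cccc(Br)c3)c2cc1OCCCN1CCNCCNCCNCC1` gives 14700 nM. Compound 2 `COc1cccc(Nc2ncnc3cc(OC)c(OCCCN4CCNCCNCCNCC4)cc23)c1` returns only a limit in this assay, > 50000 nM. Compound 3 `COc1cc2ncnc(Nc3cccc(Br)c3)c2cc1OCCCN1CCNCCNCC1` gives 34300 nM in this assay, the highest of the two numbers recorded, with compound 1 nearest to it: a 2.3-fold higher number from compound 1 to compound 3 (0.37 log units; beyond the scatter). The other measured step, an at least 3.4-fold higher number from compound 1 to compound 2 (0.53 log units; beyond the scatter), shows that a change on the aromatic ring carried by the amino nitrogen can push the number past the limit (the limit of > 50000 nM in this assay, at which 1 of the 3 values shown sits). Compound 4 `COc1cc2ncnc(Nc3ccc(Cl)cc3Cl)c2cc1OCCCN1CCNCCNCC1` differs from compound 3 as follows: 2,4-dichlorophenyl in place of 3-bromophenyl on a nitrogen on an aromatic ring. Among the compounds with values here, no measured step covers this exact exchange; the nearest comparison is the change from compound 1 to compound 2 on the same ring, which weakened the number. The step into compound 4 is therefore expected to be small to modestly weakening, a 1.3-fold higher number from compound 3 to compound 4 (0.12 log units; within the scatter), with a real chance that this assay returns only a limit. Compound 4 is estimated at 45000 nM in this assay, expected to fall between 15000 nM and 150000 nM.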

Compound 4, half-maximal inhibitory concentration: 44200 nM
Compound 4: middle estimate off by 1.0-fold (0.01 log units), on the high side, and the stated range covers the measured number.
By their numbers in this assay, from the lowest: compound 1; then compounds 3 and 4 (each within the scatter of the next). At a limit, above all of these: compound 2.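

In this assay, the step of a 1.3-fold higher number from compound 3 to compound 4 (0.11 log units; within the scatter) stays within the scatter, so on the nine-membered ring series, 2,4-dichlorophenyl in place of 3-bromophenyl on the amino nitrogen leaves the number unresolved from its starting point. Within the data shown here, the only earlier change read on this ring, methoxy in place of bromo with the larger non-aromatic ring of compound 1 present, was an at least 3.4-fold higher number from compound 1 to compound 2 (0.53 log units; beyond the scatter), so the new step shows that a change at this place need not move the number beyond the scatter. Compound 4 also returns a number rather than a limit, and so does not join compound 2 there: the limit of > 50000 nM in this assay, at which 1 of the 4 values shown sits.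

Still open, going by these compounds, is whether 2,4-dichlorophenyl would read the same with the larger non-aromatic ring of compound 1. Also open, on these data alone, is how an unsubstituted phenyl group, or a ring carrying an amine or a carboxylic acid, would read on this nitrogen.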